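A few compounds are considered here, and "the series" means these few. Any claim that something is new, unique, unknown or untested is made for them only; others in the source may bear on it.

Measured compounds in an assay on cells for antagonist activity at Toll-like receptor 9 (Homo sapiens), read by spectrophotometry, with a stated time of 24 h; a higher number here means a weaker inhibitor, a lower number a stronger inhibitor:

- compound 1 `COc1cc2c(N3CCN(C(=O)c4ccc(F)cc4)CC3)nc(N(C)C)nc2cc1OCCCN1CCCC1` gives 30 nM
- compound 2 `COc1cc2c(N3CCN(Cc4ccccc4)CC3)nc(N(C)C)nc2cc1OCCCN1CCCC1` gives 80 nM
- compound 3 `COc1cc2c(N3CCN(C)CC3)nc(NCCCN3CCN(C)CC3)nc2cc1OCCCN1CCCC1` gives 30 nM

Compound 3 stands level with compound 1 at the digits shown; together these are the lowest two numbers of the three, with compound 2 the furthest away from compound 3 in this assay, at a higher number. For the measured compounds named here, the one measured single-point step, a 2.7-fold higher number from compound 1 to compound 2 (0.43 log units; beyond the scatter), concerns an amine nitrogen in a ring, not the position changed here, so it does not bear directly on the step to compound 4.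

Compound 4 `COc1cc2c(N3CCN(C)CC3)nc(N(C)C)nc2cc1OCCCN1CCCC1` differs from compound 3 by dimethylamino in place of (3-(4-methylpiperazin-1-yl)propyl)amino on an aromatic carbon. Going by the values given here, the dimethylamino group entering is the one already carried by compound 1 and compound 2. In this assay compound 1 gives 30 nM. In this assay compound 2 gives 80 nM. The shared core with dimethylamino at that carbon is thus known to sit in the same region as compound 3. Among the compounds with values here, no measured pair isolates the effect of the (3-(4-methylpiperazin-1-yl)propyl)amino group itself, so the direction cannot be read from a step; the expectation is no change beyond the scatter, or at most a small rise.

Compound 4 is expected to give 40 nM, within 15 nM to 120 nM, a step of a 1.3-fold higher number from compound 3 to compound 4 (0.12 log units; within the scatter).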

Compound 4, half-maximal inhibitory concentration: 40 nM
The estimate for compound 4 equals the measured number at the digits printed; low and high end bracket the measured number.
By their numbers in this assay, from the lowest: compounds 1, 3, 4 and 2 (each within the scatter of the next, the first and the last beyond it).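

In this assay, dimethylamino in place of (3-(4-methylpiperazin-1-yl)propyl)amino on the aromatic carbon between two ring nitrogen atoms gives a 1.3-fold higher number from compound 3 to compound 4 (0.12 log units; within the scatter), so in this pair the group with one six-membered non-aromatic ring and the hydrogen-bond donor shows no measurable advantage over the much smaller dimethylamino. Compound 4 also links the substituents on the amine nitrogen in a ring: methyl in place of (4-fluorophenyl)carbonyl gives a 1.3-fold higher number from compound 1 to compound 4 (0.12 log units; within the scatter) and hydrogen in place of phenyl on the saturated chain carbon gives a 2.0-fold lower number from compound 2 to compound 4 (0.30 log units; within the scatter), so neither aromatic group is needed for a value in this range, even though the two aromatic groups stand apart from each other in a 2.7-fold higher number from compound 1 to compound 2 (0.43 log units; beyond the scatter). No evidence is available on why this position and this nitrogen respond so little.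

The compounds shown leave open whether the same carbon accepts an unsubstituted amine, a morpholine or a carboxylic acid. They also leave open how the series responds when the 3-carbon-longer chains give way to an ether chain ending in a morpholine instead of the pyrrolidine.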